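Cytotoxicity notes: triazole sulfonamide series, compound 2 to compound 3

The compounds below may be only part of what the source reports. "The series", "measured", "known", "first", "only" and "open" are said of these compounds alone.

Compound 1 `Cc1ccccc1-n1cc(-c2cccc(NS(=O)(=O)c3c[nH]c(=O)[nH]c3=O)c2)nn1` gives 15300 nM in an ADME assay on L02 cells (Homo sapiens) for cytotoxicity, read by MTT assay, with a stated time of 24 h; a lower number here means that less compound is tolerated, a higher number that more compound is tolerated. Compound 2 `Cc1ccccc1-n1cc(-c2ccc(NS(=O)(=O)c3c[nH]c(=O)[nH]c3=O)cc2)nn1` is reported in this assay only as "not toxic" (no number reported), with no single number, so compound 2 cannot be placed on a scale against compound 1. Compound 3 `O=c1[nH]cc(S(=O)(=O)Nc2ccc(-c3cn(-c4ccc(F)cc4)nn3)cc2)c(=O)[nH]1` differs from compound 2 by 4-fluorophenyl in place of 2-methylphenyl on an aromatic nitrogen. For the measured compounds named here, no measured pair covers this change, so no size of step in this assay is expected beyond the usual scatter, in either direction. Compound 3 is estimated at 30000 nM in this assay, expected within 8000 nM to 150000 nM, with a fair chance that only a limit is reported.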

Compound 3, half-maximal cytotoxic concentration: "not toxic" (no number reported)
For compound 3 the study gives words and no number; there is nothing to compare the estimate with.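

Compound 2 and compound 3 are both reported only in words in this assay, so no step can be read between them. No evidence bears on this result.

Still open, on these data alone, is whether 4-fluorophenyl in place of 2-methylphenyl changes tolerance on a numerical scale.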